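Phenyl for Ethyl on a Ring Nitrogen: Paw Edema

The source may report more compounds than this note shows. Statements on the series, on what has been measured and on what is new or still open speak of the compounds shown alone.

Compound 1, `COc1cc(-c2nnc(SCC(=O)Nc3ccc(/C(C)=N/O)cc3)n2-c2ccccc2)cc(OC)c1OC`: 59%
Compound 2, `CCn1c(SCC(=O)Nc2ccc(/C(C)=N/O)cc2)nnc1-c1cc(OC)c(OC)c(OC)c1`: 29%
Compound 3, `CCn1c(SCC(=O)Nc2ccc(C(C)=O)cc2)nnc1-c1ccccc1`: 50%

These three compounds were tested in a functional assay on the whole organism (strain albino) for inhibition, with Rattus norvegicus as the target, read by paw edema, with stated times of 30 min and 1 h, at a dose of 0.28 mmol/kg by the oral route; on this read-out lower numbers stand for less inhibition and higher numbers for more inhibition at the one dose given (going by the name of the read-out). Compound 2 and compound 1 share one core and differ in a single place: phenyl in place of ethyl on an aromatic nitrogen. Compound 3 carries another core; the difference between the two cores is not broken down here. The number for compound 3 lies within the scatter of the number for compound 1 and beyond the scatter of the number for compound 2.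

Compound 4, `CC(=O)c1ccc(NC(=O)CSc2nnc(-c3ccccc3)n2-c2ccccc2)cc1`, has not yet been measured. It differs from compound 3 in one place: phenyl in place of ethyl on an aromatic nitrogen. Within the data shown here, this is the same kind of change as the one from compound 2 to compound 1, but not the same change: in compound 2 the ring nitrogen is next to two ring atoms that each bear a large group, whereas in compound 3 it is next to the ring atom that bears a large group and next to the ring atom that bears a phenyl group. Among the measured compounds shown here, a rise is expected for compound 4 because the one measured example of this kind of change gave a number 30 percentage points higher from compound 2 to compound 1 (beyond the scatter), though a somewhat smaller step is expected since the surroundings of the place differ, giving a number 18 percentage points higher from compound 3 to compound 4 (beyond the scatter). Compound 4 is thus estimated at 68%, between 48% and 85%.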

Compound 4, a percentage reported as inhibition, in the whole organism at one dose (the size of the read-out at that dose, not a potency): 41%
Compound 4: middle estimate off by 27 percentage points, on the high side; the whole stated range lies above it.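

In this assay, the swap of ethyl for phenyl on the ring nitrogen does not carry over from one core to the other: the same change on two cores in this assay, a number 30 percentage points higher (beyond the scatter) from compound 2 to compound 1 and a number 9 percentage points lower (within the scatter) from compound 3 to compound 4, 39 percentage points apart, beyond the scatter of two such steps

On the core of compound 3, the swap gives a number 9 percentage points lower from compound 3 to compound 4 (within the scatter), so ethyl and phenyl cannot be told apart there, even though the same swap gave a clear rise on the core of compound 1. This shows that a step measured on one core in this series cannot simply be added to a compound with another core, but it does not show which part of the cores accounts for the gap, and two pairs are too few to give a rule for any further core.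

The compounds shown leave open how other groups on the ring nitrogen, such as a propyl chain or a benzyl group, would behave on each of the two cores. They also leave open whether the same picture would hold at another dose, as each number here comes from a single dose.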